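A few compounds are considered here, and "the series" means these few. Any claim that something is new, unique, unknown or untested is made for them only; others in the source may bear on it.

Going by the values given here, in a physicochemical assay for lipophilicity, using the shake flask method (on this read-out lower numbers stand for lower lipophilicity and higher numbers for higher lipophilicity), compound 2 (`O=C(Nc1ccc(C(F)(F)F)cc1)NC1CCN(C(=O)C2CC2)CC1`) gives 3.18, the only number so far. Among the compounds with values here, compound 1 (`CCCC(=O)N1CCC(NC(=O)Nc2ccc(C(F)(F)F)cc2)CC1`) is reported as "not determined" (no result reported), so no measured step is available to calibrate against. Compound 3 (`CC(C)CC(=O)N1CCC(NC(=O)Nc2ccc(C(F)(F)F)cc2)CC1`) has isobutyl in place of cyclopropyl on a carbonyl carbon. Taking compound 2 at 3.18 as the only anchor, a rise in this assay beyond the usual scatter is expected, though this expectation rests on the structural change alone. The estimated change is a number 0.57 log units higher from compound 2 to compound 3 (beyond the scatter). Compound 3 is expected at 3.75, with an estimated range of 3.4 to 4.1.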

Compound 3, partition coefficient: 3.86
The estimate for compound 3 lay 0.11 log units below the measured number; the measured number falls inside the stated range.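

In this assay, going by these compounds alone, isobutyl in place of cyclopropyl on a carbonyl carbon gives a number 0.68 log units higher from compound 2 to compound 3 (beyond the scatter), the first measured step. The read-out at this position therefore responds to a change of the group on that carbonyl carbon. No supporting data bear on why the number moves.

The loss of the ring and the gain in heavy atoms arrive together in this one change, so the compounds shown do not separate them. Going by these compounds, how an amine, a carboxylic acid or a longer chain at this position would read remains open.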